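One More Chlorine on the Amide Side of Compound 2

The source may hold more compounds than are shown below. What is called first, only, known or untested is meant among the compounds shown, and "the series" means these compounds.

Of the compounds shown here, two have been tested in a functional assay on KM12 cells (Homo sapiens) for inhibition, read by sulforhodamine B assay, with a stated time of 48 h; a higher number here means that more compound is tolerated, a lower number that less compound is tolerated. For compound 1 `O=C(Nc1cccc(-n2cc(-c3ccncc3)c(-c3ccc(Cl)c(O)c3)n2)c1)Nc1cccc(C(F)(F)F)c1` the result was only a limit, > 32500 nM, so no true number exists for it. For compound 2 `COc1cc(-c2nn(-c3cccc(NC(=O)c4cccc(C(F)(F)F)c4)c3)cc2-c2ccncc2)ccc1Cl` the result was likewise a limit, > 50000 nM. Going by the values given here, compound 2 therefore stands at a boundary of this assay rather than at a measured point, and the only other compound examined stands at a boundary as well, as the limit of > 32500 nM in this assay, at which 1 of the 2 values shown sits, and the limit of > 50000 nM in this assay, at which 1 of the 2 values shown sits, show. Among the compounds with values here, with both values being limits, no step between measured compounds can be given.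

Compound 3 `COc1cc(-c2nn(-c3cccc(NC(=O)c4ccc(Cl)c(C(F)(F)F)c4)c3)cc2-c2ccncc2)ccc1Cl` is the next compound to be measured. It differs from compound 2 by chloro in place of hydrogen on an aromatic carbon, in words chloro in place of hydrogen on an aromatic carbon. Since compound 2 tolerates at least the highest concentration tried, the change is expected to produce no step beyond the scatter, and compound 3 will most likely again reach only a limit. Compound 3 is estimated at 50000 nM, with a range from 20000 nM to 100000 nM. The estimated step, a number no higher from compound 2 to compound 3 (the limit leaves the size open), is expected to lie within the scatter.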

Compound 3, concentration lethal to 50% of the cells: > 32500 nM
Compound 3: no number, only a limit (the forecaster's own chance of this, stated with the estimate: 70%); the middle value is on the limit's open side.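

In this assay compound 2 and compound 3 both give only limits rather than numbers, so no step can be read between them. The compounds shown leave open whether adding the chloro changes the concentration these cells tolerate, and where the true values of compound 1, compound 2 and compound 3 lie.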